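The source may hold more compounds than are shown below. What is called first, only, known or untested is meant among the compounds shown, and "the series" means these compounds.

In a physicochemical assay for solubility, read by HPLC, at pH 7.4 (on this read-out lower numbers stand for lower solubility and higher numbers for higher solubility), compound 1 `Cc1[nH]c2ccccc2c(=O)c1Cc1ccccc1` gives 10000 nM. Compound 2 `COc1ccc2[nH]c(C)c(Cc3ccccc3)c(=O)c2c1` gives 2000 nM, and compound 3 `Cc1[nH]c2c(Cl)cccc2c(=O)c1Cc1ccccc1` gives 5000 nM. Compound 1 therefore cannot be separated from compound 3 on these numbers, and only compound 2 stands clearly apart from it.

Compound 4 `COc1ccc2c(=O)c(Cc3ccccc3)c(C)[nH]c2c1` has not yet been measured. It differs from compound 1 by methoxy in place of hydrogen on an aromatic carbon, with methoxy in place of hydrogen on an aromatic carbon, meta to a fused ring and para to a fused ring. The closest guide is compound 2, which carries the same group at a different aromatic carbon and shows a 5.0-fold lower number from compound 1 to compound 2 (0.70 log units; beyond the scatter). Compound 3 bears on it only loosely, since it carries chloro instead and shows a 2.0-fold lower number from compound 1 to compound 3 (0.30 log units; within the scatter). The data do not show how much the place of the methoxy matters, so a modest fall in this assay is expected, though it may stay close to the scatter. The expected step is a 2.9-fold lower number from compound 1 to compound 4 (0.46 log units; beyond the scatter). Compound 4 is estimated at 3500 nM, with an expected range of 1500 nM to 8000 nM.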

Compound 4, solubility: 5000 nM
The estimate for compound 4 lay 1.4-fold (0.15 log units) below the measured number; the range from low to high includes it.
By their numbers in this assay, from the lowest: compound 2; then compounds 3, 4 and 1 (each within the scatter of the next).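

At this position, meta to a fused ring and para to a fused ring, methoxy in place of hydrogen gives a 2.0-fold lower number from compound 1 to compound 4 (0.30 log units; within the scatter) in this assay, so compound 4 cannot be separated from compound 1 on these numbers. The same group on a different aromatic carbon gives a 5.0-fold lower number from compound 1 to compound 2 (0.70 log units; beyond the scatter), which shows that methoxy does not lie beyond the scatter at every place on the shared core. Nothing available explains this contrast between the two places.

The compounds shown leave open whether an amine, a carboxylic acid or a longer chain such as ethoxy at this carbon would also stay within the scatter of compound 1. They also leave open how chloro would read at this carbon and how methoxy would read on the remaining aromatic carbons.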